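A few compounds are considered here, and "the series" means these few. Any claim that something is new, unique, unknown or untested is made for them only; others in the source may bear on it.

Three compounds share one core and differ only in the group on one aromatic carbon. In an assay on brain for binding affinity to Neuronal acetylcholine receptor; alpha4/beta2 (Rattus norvegicus), read by radioligand binding (on this read-out lower numbers stand for stronger inhibition and higher numbers for weaker inhibition), compound 1 `Fc1cncc(OC[C@@H]2CCN2)c1` gives 0.076 nM, compound 2 `Cc1cncc(OC[C@@H]2CCN2)c1` gives 0.047 nM, and compound 3 `CCCc1cncc(OC[C@@H]2CCN2)c1` gives 0.039 nM. Compound 3 has the lowest of the three numbers, yet a 1.2-fold lower number from compound 2 to compound 3 (0.08 log units; within the scatter) and a 1.9-fold lower number from compound 1 to compound 3 (0.29 log units; within the scatter) are within the scatter, as is a 1.6-fold lower number from compound 1 to compound 2 (0.21 log units; within the scatter), so no ranking can be claimed. Compound 4 `CC(=O)NCc1cncc(OC[C@@H]2CCN2)c1` carries acetamido in place of ethyl on a saturated chain carbon bound to an aromatic carbon. Going by the values given here, no measured step brings in a group with a hydrogen-bond donor or acceptor; the nearest comparison, a 1.2-fold lower number from compound 2 to compound 3 (0.08 log units; within the scatter), only lengthened a chain. Lacking a direct guide, a modest move toward a higher number is expected, a 3.8-fold higher number from compound 3 to compound 4 (0.59 log units; beyond the scatter). Compound 4 is estimated at 0.15 nM, with a range from 0.04 nM to 0.6 nM.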

Compound 4, inhibition constant: 0.54 nM
Beside the measured number, compound 4's estimate is 3.6-fold (0.56 log units) below it; low and high end bracket the measured number.
By their numbers in this assay, from the lowest: compounds 3, 2 and 1 (each within the scatter of the next); then compound 4.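

Until now, every change of the group on this aromatic carbon stayed within the scatter, but acetamidomethyl moves the number beyond it in all three comparisons (a 14-fold higher number from compound 3 to compound 4 (1.14 log units; beyond the scatter)) (an 11-fold higher number from compound 2 to compound 4 (1.06 log units; beyond the scatter)) (a 7.1-fold higher number from compound 1 to compound 4 (0.85 log units; beyond the scatter)). So this position does not treat every group alike, and the first group here with a hydrogen-bond donor and acceptor gives the highest number of the four. No measurement here explains that rise.

Still open, going by these compounds, is whether an aminomethyl group or a longer chain such as butyl would stay with compound 3 or go with compound 4.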